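A few compounds are considered here, and "the series" means these few. Any claim that something is new, unique, unknown or untested is made for them only; others in the source may bear on it.

Values in a physicochemical assay for solubility, using the shake flask method, in phosphate buffer, measured as kinetic solubility, with a stated time of 20 h, at pH 6.5 (on this read-out lower numbers stand for lower solubility and higher numbers for higher solubility), as measured:
- compound 1 `FC(F)(F)c1ccc(Nc2cc3[nH]c(-c4cccc(C(F)(F)F)c4)nc3cn2)nc1` gives < 5000 nM as a limit
- compound 2 `FC(F)(F)c1cccc(-c2nc3cnc(Nc4ccc(-c5nnn[nH]5)cn4)cc3[nH]2)c1` gives < 5000 nM as a limit

Compound 1 is known only as a limit, with no number to step from (the limit of < 5000 nM in this assay, at which 2 of the 2 values shown sit). Compound 3 `FC(F)(F)c1ccc(Nc2cc3[nH]c(C4CCOC4)nc3cn2)nc1` carries oxolan-3-yl in place of 3-(trifluoromethyl)phenyl on an aromatic carbon. Within the data shown here, the only measured step (a step that the two limits leave unreadable from compound 1 to compound 2) has no readable size, so it gives no guide to the size of this one. The expected upward step in this assay is estimated as an at least 3.0-fold higher number from compound 1 to compound 3 (0.47 log units; beyond the scatter) with wide uncertainty. The estimate for compound 3 is 15000 nM with an expected range from 5000 nM to 60000 nM as the likely outcome.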

Compound 3, solubility: 166000 nM
Compound 3: middle estimate off by 11-fold (1.04 log units), on the low side; the measured number lies above the stated range.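

At the aromatic carbon between two ring nitrogen atoms, the solubility read-out in this assay proves highly sensitive to the substituent: oxolan-3-yl in place of 3-(trifluoromethyl)phenyl gives an at least 33-fold higher number from compound 1 to compound 3 (1.52 log units; beyond the scatter). The size of this step remains a minimum, and compound 3 is the only compound shown with a value that is not a limit: the limit of < 5000 nM in this assay, at which 2 of the 3 values shown sit.

As far as these compounds go, the step from compound 1 to compound 2 cannot be read, so the effect of the tetrazolyl change remains open. Whether the ring oxygen or the loss of the aromatic ring accounts for the step also remains open, and a cyclopentyl group at this carbon would separate the two.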